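The source may report more compounds than this note shows. Statements on the series, on what has been measured and on what is new or still open speak of the compounds shown alone.

Compound 1, `CC[C@H](C)C(=O)O[C@H]1C[C@@H](C)C=C2C=C[C@H](C)[C@H](CC[C@@H](O)C[C@@H](CC(=O)NO)OC(C)=O)[C@H]21`, gives 11400 nM in a functional assay on PC-3 cells (Homo sapiens) for inhibition, read by sulforhodamine B assay, with a stated time of 48 h; a lower number here means a stronger inhibitor, a higher number a weaker inhibitor.
Compound 2, `CC[C@H](C)C(=O)O[C@H]1C[C@@H](C)C=C2C=C[C@H](C)[C@H](CC[C@@H](O)C[C@@H](CC(=O)NO)OC(=O)C(C)(C)C)[C@H]21`, gives 7200 nM in this assay.
Compound 3, `CC[C@H](C)C(=O)O[C@H]1C[C@@H](C)C=C2C=C[C@H](C)[C@H](CC[C@@H](O)C[C@@H](CC(=O)NO)OC(=O)c3ccc(OC(F)(F)F)cc3)[C@H]21`, gives 20300 nM in this assay.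

All three share one core and differ only in the group on the carbonyl carbon of an ester. Among the compounds with values here, the one step beyond the scatter is a 2.8-fold higher number from compound 2 to compound 3 (0.45 log units; beyond the scatter); a 1.8-fold higher number from compound 1 to compound 3 (0.25 log units; within the scatter) and a 1.6-fold lower number from compound 1 to compound 2 (0.20 log units; within the scatter) both fall within it, so the ester group has so far moved the numbers only a little. Compound 4, `CC[C@H](C)C(=O)O[C@H]1C[C@@H](C)C=C2C=C[C@H](C)[C@H](CC[C@@H](O)C[C@@H](CC(=O)NO)OC(=O)c3ccc(Cl)cc3)[C@H]21`, keeps the aryl ester of compound 3 and alters it by chloro in place of trifluoromethoxy on an aromatic carbon. Within the data shown here, no measured step exchanges one group on that ring for another, so nothing directly bears on this change. Every step seen so far stayed small, so compound 4 is expected to show a 1.4-fold lower number from compound 3 to compound 4 (0.13 log units; within the scatter). Compound 4 is estimated at 15000 nM, with a range from 6000 nM to 40000 nM.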

Compound 4, half-maximal inhibitory concentration: 21700 nM
Compound 4: middle estimate off by 1.4-fold (0.16 log units), on the low side, within the range that was stated.
By their numbers in this assay, from the lowest: compounds 2, 1, 3 and 4 (each within the scatter of the next, the first and the last beyond it).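

In this assay, swapping trifluoromethoxy for chloro on the aromatic ring gives a 1.1-fold higher number from compound 3 to compound 4 (0.03 log units; within the scatter), so this assay does not separate these two groups at this position, although chloro has one heavy atom and trifluoromethoxy five. The 4-chlorophenyl ester also repeats what the other aryl ester showed against the tert-butyl ester, with a 3.0-fold higher number from compound 2 to compound 4 (0.48 log units; beyond the scatter). Against the methyl ester, the result is a 1.9-fold higher number from compound 1 to compound 4 (0.28 log units; within the scatter).

No measurement shown explains these results. As far as these compounds go, it remains open whether an amine or a carboxylic acid at this ring position would shift the number.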